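Sulfanyl in Place of Hydroxy on the Shared Core

The compounds below may be only part of what the source reports. "The series", "measured", "known", "first", "only" and "open" are said of these compounds alone.

Measured compounds:
Compound 1 `COCc1ncc2cnnc(S)n12`: in a functional assay for inhibition, with Homo sapiens as the target (a lower number here means a stronger inhibitor, a higher number a weaker inhibitor), compound 1 gives > 48000 nM, which is a limit of the assay.
Compound 2 `Cc1ncc2cnnc(O)n12`: in this assay compound 2 gives > 48000 nM, again a limit of the assay and not a number.

Compound 2 therefore stands at the limit of this assay, with no number of its own; both values shown sit there, as the limit of > 48000 nM in this assay, at which 2 of the 2 values shown sit, states. Compound 3 `Cc1ncc2cnnc(S)n12` differs from compound 2 by sulfanyl in place of hydroxy on an aromatic carbon. Within the data shown here, no step between measured compounds is known, so the size of this change cannot be read from a measured pair. Compound 1 also carries the sulfanyl group and sits at the limit in this assay. Compound 3 is thus expected to stay at the limit as well, with no step beyond the scatter, a step that the limit leaves unreadable from compound 2 to compound 3 being the expected change. Compound 3 is estimated at 70000 nM in this assay, within a range of 20000 nM to 250000 nM.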

Compound 3, half-maximal inhibitory concentration: > 48000 nM
Compound 3: a limit, no number; the forecaster's own chance of this, stated with the estimate: 85%; the middle value lies beyond the limit too.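

No step can be read from compound 2 to compound 3 or from compound 1 to compound 3, because all three compounds stand at a limit in this assay and not at a number: the limit of > 48000 nM in this assay, at which 3 of the 3 values shown sit.

The compounds shown leave open how sulfanyl and hydroxy compare in this assay on the shared core, and whether any compound with this core gives a number there.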